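Replacing a Hydroxy Group: Expected Cytotoxicity of Compound 4

The source may hold more compounds than are shown below. What is called first, only, known or untested is meant among the compounds shown, and "the series" means these compounds.

Of the compounds shown here, three sharing one core have been tested in an ADME assay on L02 cells (Homo sapiens) for cytotoxicity, read by MTT assay; a lower number here means a stronger inhibitor, a higher number a weaker inhibitor. Compound 1, `COc1ccc(/C=C/C(=O)c2ccc(OC)c3c2OC(C)(C)C=C3)cc1O`, gives > 10000 nM, which is a limit of the assay rather than a number. Compound 2, `C=CC(=O)Oc1cc(/C=C/C(=O)c2ccc(OC)c3c2OC(C)(C)C=C3)ccc1OC`, gives > 10000 nM, also a limit. Compound 3, `COc1cccc(C(=O)Oc2cc(/C=C/C(=O)c3ccc(OC)c4c3OC(C)(C)C=C4)ccc2OC)c1`, gives > 10000 nM, again a limit. The steps among them, a step that the two limits leave unreadable from compound 1 to compound 2, a step that the two limits leave unreadable from compound 1 to compound 3 and a step that the two limits leave unreadable from compound 2 to compound 3, therefore cannot be sized; all three values sit at the limit of > 10000 nM in this assay, at which 3 of the 3 values shown sit.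

Compound 4, `COc1ccc(/C=C/C(=O)c2ccc(OC)c3c2OC(C)(C)C=C3)cc1CS(C)(=O)=O`, differs from compound 1 by (methylsulfonyl)methyl in place of hydroxy on an aromatic carbon. Among the compounds with values here, no measured step involves this kind of change, and the steps from compound 1 to compounds 2 and 3 are all unreadable, so there is no evidence of a direction or size for the step to compound 4. Since compound 1 sits at a limit, compound 4 is expected to remain there as well, and the expected step is a step that the limit leaves unreadable from compound 1 to compound 4. The estimate for compound 4 in this assay is 20000 nM, between 8000 nM and 50000 nM.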

Compound 4, half-maximal inhibitory concentration: > 10000 nM
Compound 4: no number, only a limit (the forecaster's own chance of this, stated with the estimate: 80%); the middle value is on the limit's open side.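

Compound 4 gives only a limit in this assay, as do compound 1, compound 2 and compound 3, so none of the steps to compound 4 can be read: the limit of > 10000 nM in this assay, at which 4 of the 4 values shown sit.

The compounds shown leave open whether any change at this place on the shared core would give a readable number, and in which direction it would move.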